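The source may report more compounds than this note shows. Statements on the series, on what has been measured and on what is new or still open speak of the compounds shown alone.

Among the measured compounds shown here, compound 1 `O=C(Nc1ccc(Oc2ccnc3[nH]ccc23)cc1)c1cn(-c2ccc(F)cc2)c2ccccc2c1=O` gives 450 nM in a functional assay on HepG2 cells (Homo sapiens) for inhibition, read by MTT assay, with a stated time of 72 h (a higher number here means a weaker inhibitor, a lower number a stronger inhibitor), the lowest of the three numbers so far. Compound 2 `O=C(Nc1ccc(Oc2ccnc3[nH]ccc23)cc1)c1cn(-c2ccc(Br)cc2F)c2ccccc2c1=O` gives 790 nM, a step of a 1.8-fold higher number from compound 1 to compound 2 (0.24 log units; within the scatter); compound 3 `O=C(Nc1ccc(Oc2ccnc3[nH]ccc23)cc1)c1cn(-c2ccc(F)c(Cl)c2)c2ccccc2c1=O` gives 1120 nM, a step of a 2.5-fold higher number from compound 1 to compound 3 (0.40 log units; beyond the scatter). Compound 4 `COc1ccc(-n2cc(C(=O)Nc3ccc(Oc4ccnc5[nH]ccc45)cc3)c(=O)c3ccccc32)cc1` differs from compound 1 by methoxy in place of fluoro on an aromatic carbon. The measured steps all exchange halogens on the ring held by the aromatic nitrogen and none brings in a methoxy, so they bear on this change only loosely; both changes to that ring gave a higher number, one within the scatter and one modestly beyond it. A similar or slightly higher number is therefore expected for compound 4, a step of a 1.4-fold higher number from compound 1 to compound 4 (0.16 log units; within the scatter). Compound 4 is estimated at 650 nM, within the range 250 nM to 1700 nM.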

Compound 4, half-maximal inhibitory concentration: 5950 nM
For compound 4 the middle estimate is 9.2-fold (0.96 log units) below the measured one; the whole stated range lies below it.
By their numbers in this assay, from the lowest: compounds 1, 2 and 3 (each within the scatter of the next, the first and the last beyond it); then compound 4.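

In this assay, methoxy in place of fluoro at this position, para to a large group, gives the largest step seen so far (a 13-fold higher number from compound 1 to compound 4 (1.12 log units; beyond the scatter)). Compound 4 also stands clearly apart from the two other halogen-bearing compounds (a 7.5-fold higher number from compound 2 to compound 4 (0.88 log units; beyond the scatter); a 5.3-fold higher number from compound 3 to compound 4 (0.73 log units; beyond the scatter)), so this ring responds far more to this change than the halogen exchanges had shown. Nothing available here explains the size of this step. Still open, going by these compounds, is whether a hydroxyl, an amine or a longer chain such as ethoxy at this position would give a number nearer that of compound 1 or that of compound 4.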